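A few compounds are considered here, and "the series" means these few. Any claim that something is new, unique, unknown or untested is made for them only; others in the source may bear on it.

Working notes on the series.

Two members of the series have been measured so far. Compound 1 `O=C(O)Cc1ccc(NC(=O)C(C2CCCCC2)n2c(-c3ccc(Cl)cc3)nc3cc(F)c(F)cc32)cc1` gives 1400 nM in an assay on isolated protein for displacement of a labelled ligand from Bile acid receptor (Homo sapiens), read by scintillation proximity assay and radioligand binding; a higher number here means a weaker inhibitor, a lower number a stronger inhibitor. Compound 2 `O=C(O)CCc1ccc(NC(=O)C(C2CCCCC2)n2c(-c3ccc(Cl)cc3)nc3cc(F)c(F)cc32)cc1` gives 60 nM in this assay, the lower of the two numbers, and the step of a 23-fold lower number from compound 1 to compound 2 (1.37 log units; beyond the scatter) separates them.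

The next member is compound 3 `O=C(O)c1ccc(NC(=O)C(C2CCCCC2)n2c(-c3ccc(Cl)cc3)nc3cc(F)c(F)cc32)nc1`. It differs from compound 2 by 5-carboxypyridin-2-yl in place of 4-(2-carboxyethyl)phenyl on an amide-type nitrogen. This is a combined change: the acid group is pulled back onto the ring itself, and the ring that carries it gains a ring nitrogen. Among the measured compounds shown here, only the one step already measured bears on it, and only in part: the step of a 23-fold lower number from compound 1 to compound 2 (1.37 log units; beyond the scatter) shows that moving the acid from directly on the ring to a longer chain gave a much lower number. Compound 3 has the acid directly on the ring again, with the acid chain shorter even than in compound 1, so the expectation is a move in the opposite direction, toward a higher number. Nothing in the data speaks to the ring nitrogen.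

For compound 3 the expected step is a 33-fold higher number from compound 2 to compound 3 (1.52 log units; beyond the scatter), and the expected value in this assay is 2000 nM, within a range of 400 nM to 10000 nM.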

Compound 3, half-maximal inhibitory concentration: 200 nM
Beside the measured number, compound 3's estimate is 10-fold (1.00 log units) above it, and the stated range ends above it.
By their numbers in this assay, from the lowest: compound 2; then compound 3; then compound 1.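

The order at the amide-type nitrogen does not follow the length of the acid chain alone: 5-carboxypyridin-2-yl, which has the acid directly on the ring, gives a 7.0-fold lower number from compound 1 to compound 3 (0.85 log units; beyond the scatter) in this assay even though 4-(carboxymethyl)phenyl carries a chain. Against the longer 4-(2-carboxyethyl)phenyl, the same group gives a 3.3-fold higher number from compound 2 to compound 3 (0.52 log units; beyond the scatter), so compound 3 falls between the two phenyl members and compound 2 keeps the lowest number of the three. Each step changes both the ring and the acid chain, so neither step can be assigned to one of those changes, and no measurement is at hand that would explain the order.

Still open, going by these compounds, is how the ring nitrogen and the acid chain each contribute, which a phenyl ring bearing the carboxylic acid directly and a pyridinyl ring bearing a carboxyethyl chain would separate. Also open, on these data alone, is whether the carboxylic acid itself is required on this group, with a primary amide or a tetrazole as the direct comparison.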